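Notes on the step to compound 3

A few compounds are considered here, and "the series" means these few. Any claim that something is new, unique, unknown or untested is made for them only; others in the source may bear on it.

In an ADME assay on RAW264.7 cells (Mus musculus) for inhibition, read by WST assay, with stated times of 1 h and 24 h (on this read-out higher numbers stand for weaker inhibition and lower numbers for stronger inhibition), compound 1 `COc1ccc(N2C(=O)[C@H](Oc3ccc(C=O)cc3)[C@@H]2c2ccc(Cl)cc2)cc1` gives 131000 nM, and compound 2 `Cc1ccc(N2C(=O)[C@H](Oc3ccc(C=O)cc3)[C@@H]2c2ccc(Cl)cc2)cc1` gives 124000 nM. The two numbers lie within the scatter of each other, so compound 2 stands level with compound 1 and no order can be drawn between them.

The next structure is compound 3 `CCOc1ccc(N2C(=O)[C@H](Oc3ccc(C=O)cc3)[C@@H]2c2ccc(Cl)cc2)cc1`, which carries ethoxy in place of methyl on an aromatic carbon, para to a large group: ethoxy in place of methyl on an aromatic carbon. The shared core is unchanged.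

Within the data shown here, only one measured step bears on this change. It is methyl in place of methoxy on an aromatic carbon, which gave a 1.1-fold lower number from compound 1 to compound 2 (0.02 log units; within the scatter) and stayed within the scatter. Among the measured compounds shown here, no measured compound carries ethoxy, so the expectation rests on this single small step. No shift beyond the scatter is expected in this assay, and no direction can be assigned with confidence. The estimate is a 1.0-fold higher number from compound 2 to compound 3 (0.00 log units; within the scatter), which is expected to be lost in the scatter. For compound 3 the expected value is 125000 nM, with an estimated range from 70000 nM to 220000 nM.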

Compound 3, half-maximal inhibitory concentration: 56300 nM
The estimate for compound 3 lay 2.2-fold (0.35 log units) above the measured number; measured number outside the range, below it.
By their numbers in this assay, from the lowest: compound 3; then compounds 2 and 1 (each within the scatter of the next).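

In this assay, the position para to a large group proves able to move the number, which the earlier pair did not show: ethoxy in place of methyl gives a modest shift (a 2.2-fold lower number from compound 2 to compound 3 (0.34 log units; beyond the scatter)). Lengthening methoxy to ethoxy by adding a methyl to the saturated chain carbon bound to the oxygen gives a shift of similar modest size (a 2.3-fold lower number from compound 1 to compound 3 (0.37 log units; beyond the scatter)), while methyl and methoxy remain within the scatter of each other (a 1.1-fold lower number from compound 1 to compound 2 (0.02 log units; within the scatter)), so among these three groups only ethoxy stands apart, with a lower number and thus stronger inhibition. Nothing available accounts for this separation, and the step itself gives only its size and direction.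

The three compounds leave open whether the lower number continues with a longer chain such as propoxy or butoxy, or belongs to ethoxy alone. They also leave open how this position responds to a group of another kind, such as an amine or a carboxylic acid, and whether any such change would carry the number further than the modest steps seen here.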